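A few compounds are considered here, and "the series" means these few. Any claim that something is new, unique, unknown or untested is made for them only; others in the source may bear on it.

Compounds measured so far:
compound 1, `COc1cccc(CN2Cc3c(NC(=O)c4ccccc4)n[nH]c3C2(C)C)c1`, 1120 nM
compound 2, `CC1(C)c2[nH]nc(NC(=O)c3ccccc3)c2CN1Cc1cc(F)cc(F)c1`, 190 nM
compound 3, `Cc1ccc(CN2Cc3c(NC(=O)c4ccccc4)n[nH]c3C2(C)C)cc1F`, 940 nM

All three share one core and differ only in the aromatic group on a saturated chain carbon bound to an amine nitrogen in a ring. In an assay on Sf21 cells for inhibition of high affinity nerve growth factor receptor (Homo sapiens), read by HTRF, with a stated time of 30 min, in the presence of a further agent that is not named here (a lower number here means a stronger inhibitor, a higher number a weaker inhibitor), compound 3 sits second highest of the three numbers: its nearest neighbour is compound 1, with a 1.2-fold lower number from compound 1 to compound 3 (0.08 log units; within the scatter), and its furthest is compound 2, with a 4.9-fold higher number from compound 2 to compound 3 (0.69 log units; beyond the scatter).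

Compound 4, `Cc1ccc(F)c(CN2Cc3c(NC(=O)c4ccccc4)n[nH]c3C2(C)C)c1`, is built from the same atoms as compound 3, joined differently: 2-fluoro-5-methylphenyl in place of 3-fluoro-4-methylphenyl on a saturated chain carbon bound to an amine nitrogen in a ring. Going by the values given here, no measured pair isolates such a rearrangement of fluorine and methyl on the same ring. Among the compounds with values here, the steps that bear on it are those where the aromatic group was swapped in the same place: from compound 1 to compound 3 the number barely moved, while a 5.9-fold lower number from compound 1 to compound 2 (0.77 log units; beyond the scatter) shows that a different fluorine pattern can shift it modestly. With only a repositioning of the same two substituents, the expected step of a 1.2-fold lower number from compound 3 to compound 4 (0.07 log units; within the scatter) in this assay is small, likely within the scatter, in no firm direction. Compound 4 is therefore estimated at 800 nM, within a range from 300 nM to 2500 nM.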

Compound 4, half-maximal inhibitory concentration: 880 nM
For compound 4 the middle estimate is 1.1-fold (0.04 log units) below the measured one, within the range that was stated.
By their numbers in this assay, from the lowest: compound 2; then compounds 4, 3 and 1 (each within the scatter of the next).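

Swapping 3-fluoro-4-methylphenyl for 2-fluoro-5-methylphenyl, with the same two substituents rearranged on the ring, gives no readable difference in this assay, with a 1.1-fold lower number from compound 3 to compound 4 (0.03 log units; within the scatter), and the 3-methoxyphenyl group of compound 1 is no different either, with a 1.3-fold lower number from compound 1 to compound 4 (0.10 log units; within the scatter). The one clear separation at this position is still the one involving the 3,5-difluorophenyl group, now seen again with a 4.6-fold higher number from compound 2 to compound 4 (0.67 log units; beyond the scatter), so the fluorine-and-methyl ring stays apart from compound 2 in both of its arrangements. No other measurement accompanies these numbers to explain why these two arrangements read alike.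

The four rings shown leave open how a plain phenyl, a ring with a single fluorine, or a 3,5-dimethylphenyl would compare, and so whether the second fluorine or the absence of a methyl or methoxy group sets compound 2 apart. Also open, going by these compounds, is whether a 3,5-dichlorophenyl or a pyridine ring in the same place would follow compound 2 or stay with compounds 1, 3 and 4.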